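The source may report more compounds than this note shows. Statements on the series, on what has been measured and on what is new or still open speak of the compounds shown alone.

Measured compounds:
compound 1, `O=C(Nc1ccc(Cl)cc1CN1C(=O)c2ccccc2C1=O)c1cccnc1`: < 1000 nM
compound 2, `O=C(Nc1ccc(Cl)cc1CN1C(=O)c2ccccc2C1=O)c1ccco1`: < 1000 nM
compound 3, `COc1ccccc1C(=O)Nc1ccc(Cl)cc1CN1C(=O)c2ccccc2C1=O`: < 1000 nM

In an assay on CHO cells for positive allosteric modulation of metabotropic glutamate receptor 5 (Rattus norvegicus), read by FLIPR (on this read-out lower numbers stand for an effect already at smaller amounts and higher numbers for an effect only at larger amounts of compound), compound 1 gives < 1000 nM, which is a limit of the assay and not a number. For compound 2 the value < 1000 nM is likewise a limit. For compound 3, too, < 1000 nM is a limit. All three share (the limit of < 1000 nM in this assay, at which 3 of the 3 values shown sit), so the steps a step that the two limits leave unreadable from compound 1 to compound 2, a step that the two limits leave unreadable from compound 1 to compound 3 and a step that the two limits leave unreadable from compound 2 to compound 3 cannot be sized; the three substituents on the carbonyl carbon are indistinguishable on the numbers shown.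

Compound 4, `O=C(Nc1ccc(Cl)cc1CN1C(=O)c2ccccc2C1=O)c1cccnn1`, has not yet been measured. It differs from compound 1 by pyridazin-3-yl in place of pyridin-3-yl on a carbonyl carbon. Among the measured compounds shown here, no measured step bears directly on this change; the only reading available is that every measured variation at the carbonyl carbon returned the same limit. Compound 4 is therefore expected to do the same, with the step that the limit leaves unreadable from compound 1 to compound 4 estimated to lie within the scatter. The value of compound 4 in this assay is estimated at 400 nM, in the range 80 nM to 2000 nM.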

Compound 4, half-maximal effective concentration: < 1000 nM
Compound 4: no number, only a limit; the forecaster's own chance of this, stated with the estimate: 70%; the middle value is on the limit's open side.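

In this assay compound 4 gives < 1000 nM, which is a limit and not a number. Its steps from compound 1, compound 2 and compound 3 therefore cannot be read: the limit of < 1000 nM in this assay, at which 4 of the 4 values shown sit.

The compounds shown leave open how the four groups on the carbonyl carbon compare, if they differ at all.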